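This account rests on a few compounds, and the source may have more. Where it says the series, first, only, none or still open, it means among the compounds named here.

Compound 1, with the structure `O=C(/C=C/c1ccccc1)NS(=O)(=O)c1ccc(Cl)cc1`, is the reference point of this small set. In a functional assay on B16-F10 cells (Mus musculus) for antiproliferative activity, read by ELISA and MTT assay, with a stated time of 48 h (on this read-out lower numbers stand for stronger inhibition and higher numbers for weaker inhibition), compound 1 gives 2.2 ug/mL. Compound 2, with the structure `O=C(/C=C/c1ccccc1)NS(=O)(=O)c1ccc(Br)cc1`, differs from it only by the change (bromo in place of chloro on an aromatic carbon). In this assay compound 2 gives 3.9 ug/mL. The resulting step, a 1.8-fold higher number from compound 1 to compound 2 (0.25 log units; within the scatter), is too small to count as a real difference between the two.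

Compound 3, with the structure `O=C(/C=C/c1ccc([N+](=O)[O-])cc1)NS(=O)(=O)c1ccc(Cl)cc1`, stands on a different core. Its core differs from that of compound 1 by the change (nitro in place of hydrogen on an aromatic carbon). In this assay compound 3 gives 13.7 ug/mL, and the step of a 6.2-fold higher number from compound 1 to compound 3 (0.79 log units; beyond the scatter) is large enough to be trusted. Compound 3 therefore shows the weakest inhibition of the three measured compounds, with both of its steps to the others lying beyond the scatter.

Compound 4, with the structure `O=C(/C=C/c1ccc([N+](=O)[O-])cc1)NS(=O)(=O)c1ccc(Br)cc1`, has not yet been measured. It differs from compound 3 by the change (bromo in place of chloro on an aromatic carbon). The place is described in exactly the same words as for the change from compound 1 to compound 2, so this is the same change applied to the other core. The step of a 1.5-fold higher number from compound 3 to compound 4 (0.16 log units; within the scatter) is expected to be of about the same small size as the earlier one, because a 1.8-fold higher number from compound 1 to compound 2 (0.25 log units; within the scatter) showed that this exchange barely moved the number. Compound 4 is accordingly estimated at 20 ug/mL, with a range from 9 ug/mL to 45 ug/mL.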

Compound 4, half-maximal inhibitory concentration: 13.9 ug/mL
Compound 4: middle estimate off by 1.4-fold (0.16 log units), on the high side, and the stated range covers the measured number.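

Exchanging chloro for bromo on the nitro-bearing core gives a 1.0-fold higher number from compound 3 to compound 4 (0.01 log units; within the scatter) in this assay, and this small step agrees with the one seen on the core of compound 1: the same change on two cores in this assay, a 1.8-fold higher number (0.25 log units; within the scatter) from compound 1 to compound 2 and a 1.0-fold higher number (0.01 log units; within the scatter) from compound 3 to compound 4, 1.7-fold (0.24 log units) apart, within the scatter of two such steps. Adding the nitro group to the bromo compound gives a 3.6-fold higher number from compound 2 to compound 4 (0.55 log units; beyond the scatter), and this larger step agrees with the one seen on the chloro compounds: the same change on two cores in this assay, a 6.2-fold higher number (0.79 log units; beyond the scatter) from compound 1 to compound 3 and a 3.6-fold higher number (0.55 log units; beyond the scatter) from compound 2 to compound 4, 1.7-fold (0.24 log units) apart, within the scatter of two such steps. Within these four compounds, then, each change carries over from one core to the other: the halogen exchange stays within the scatter on both cores, while the nitro group weakens inhibition beyond the scatter on both, but each conclusion rests on only two pairs in a single cell assay and does not explain why the numbers move or show that the pattern extends to other groups or cores.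

The compounds shown leave open whether fluoro would behave like chloro and bromo, and whether an amine or a methoxy group in place of the nitro group would also weaken inhibition. From the compounds shown here alone, it also remains open whether these steps would hold with a carboxylic acid on the ring or with a longer chain in place of the double bond of the shared core.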